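Swapping the Ketone Aryl Group: Bromine Out, Methyl In

The source may report more compounds than this note shows. Statements on the series, on what has been measured and on what is new or still open speak of the compounds shown alone.

Of the compounds shown here, three sharing one core have been tested in a functional assay on MCF7 cells (Homo sapiens) for cytotoxicity, read by MTT assay, with a stated time of 48 h; on this read-out lower numbers stand for stronger inhibition and higher numbers for weaker inhibition. Compound 1 `COc1cc(-c2nnc3n2NC(c2cccs2)C(C(=O)c2ccc(F)cc2)S3)cc(OC)c1OC` gives 43700 nM. Compound 3 `COc1ccc(C(=O)C2Sc3nnc(-c4cc(OC)c(OC)c(OC)c4)n3NC2c2cccs2)cc1` gives 49500 nM. Compound 2 `COc1cc(-c2nnc3n2NC(c2ccco2)C(C(=O)c2cccc(Br)c2)S3)cc(OC)c1OC` gives 91800 nM, the highest of the three numbers; its gap to compound 3 lies within the scatter, its gap to compound 1 just beyond it.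

Compound 4 `COc1cc(-c2nnc3n2NC(c2ccco2)C(C(=O)c2ccccc2C)S3)cc(OC)c1OC` is not yet measured. It differs from compound 2 in one place: 2-methylphenyl in place of 3-bromophenyl on a carbonyl carbon.

For the measured compounds named here, the only measured step that touches the same part of the molecule is the one from compound 1 to compound 3, where a methoxy replaced a fluoro on an aromatic carbon of the same aryl group and gave a 1.1-fold higher number from compound 1 to compound 3 (0.05 log units; within the scatter). That single example suggests that changing the substituent on this aryl ring moves the number little. Going by the values given here, no step involving a methyl group or a change of ring position exists among the measured compounds, so the expectation rests on that one comparison alone.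

Compound 4 is therefore expected to give about 75000 nM, with a plausible range from 35000 nM to 160000 nM. In terms of the step, the expected change is a 1.2-fold lower number from compound 2 to compound 4 (0.09 log units; within the scatter), which is not expected to go beyond the scatter.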

Compound 4, half-maximal inhibitory concentration: 69900 nM
Compound 4: middle estimate off by 1.1-fold (0.03 log units), on the high side, and the stated range covers the measured number.
By their numbers in this assay, from the lowest: compounds 1, 3, 4 and 2 (each within the scatter of the next, the first and the last beyond it).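

In this assay, replacing 3-bromophenyl with 2-methylphenyl on the carbonyl carbon gives a 1.3-fold lower number from compound 2 to compound 4 (0.12 log units; within the scatter), so this exchange does not separate the two compounds. This is a second case, alongside a 1.1-fold higher number from compound 1 to compound 3 (0.05 log units; within the scatter), in which a change to the aryl group on the carbonyl stays within the scatter, and here both the substituent and its place on the ring differ. Because those two differences arrive together in one step, the data cannot assign any share of the small gap to either one, and nothing available explains the result.

The compounds shown leave open whether this aryl group tolerates every change or only those tried so far. An amine, a carboxylic acid or a longer chain on this ring could still move the number well beyond the scatter.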